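This account rests on a few compounds, and the source may have more. Where it says the series, first, only, none or still open, it means among the compounds named here.

Measured in an assay on isolated protein for activation of cGMP-dependent protein kinase 1 (Homo sapiens), read by ADP-Glo, with stated times of 30 min and 2 h, in the presence of a further agent that is not named here; a lower number here means that less compound is needed, a higher number that more compound is needed for the effect:
compound 1 `O=C(O)C12CC(CN3CCC[C@H](O[C@H](CO)c4cc(Cl)cc(Cl)c4)[C@@H]3c3ccccc3)(C1)C2`: 12000 nM
compound 2 `Cc1cc(C(=O)O)ccc1CN1CCC[C@H](O[C@H](CO)c2cc(F)cc(F)c2)[C@@H]1c1ccccc1`: 1500 nM
compound 3 `O=C(O)c1ccc(CN2CCC[C@H](O[C@H](CO)c3cc(Cl)cc(Cl)c3)[C@@H]2c2ccccc2)c(C2CC2)c1`: 1800 nM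

Compound 2 gives the lowest of the three numbers; compound 3 sits within the scatter of it, while compound 1 lies beyond the scatter above it. Among the measured compounds shown here, the only single-point step measured is a 6.7-fold lower number from compound 1 to compound 3 (0.82 log units; beyond the scatter), which concerns the group on the amine nitrogen in a ring, not the halogenated aryl.

Compound 4 `Cc1cc(C(=O)O)ccc1CN1CCC[C@H](O[C@H](CO)c2cccc(Cl)c2)[C@@H]1c1ccccc1` differs from compound 2 by 3-chlorophenyl in place of 3,5-difluorophenyl on a saturated chain carbon bound to an oxygen on a saturated carbon and a saturated chain carbon. For the measured compounds named here, no measured pair isolates this change: compounds 1 and 3 differ from compound 2 at this aryl but also at the group on the ring nitrogen, so their values say nothing clean about it. Going by the values given here, with no bearing step, the expected change from compound 2 is none beyond the scatter, the estimated step being a 1.2-fold higher number from compound 2 to compound 4 (0.08 log units; within the scatter). Compound 4 is therefore expected near 1800 nM, within 700 nM to 5000 nM.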

Compound 4, half-maximal effective concentration: 1300 nM
Beside the measured number, compound 4's estimate is 1.4-fold (0.14 log units) above it, within the range that was stated.
By their numbers in this assay, from the lowest: compounds 4, 2 and 3 (each within the scatter of the next); then compound 1.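

In this assay, 3-chlorophenyl in place of 3,5-difluorophenyl on a saturated chain carbon bound to an oxygen on a saturated carbon and a saturated chain carbon gives a 1.2-fold lower number from compound 2 to compound 4 (0.06 log units; within the scatter). Among the compounds shown here, this is the first reading of this position with the group on the ring nitrogen held constant, and it does not tell the two halogenated aryl groups apart. No measurement on hand offers an explanation for this result.
As far as these compounds go, whether unsubstituted phenyl, a methoxyphenyl or a cyclohexyl group at this position would read the same remains open. So does whether 3-chlorophenyl and 3,5-difluorophenyl would also match with another group on the ring nitrogen.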